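This account rests on a few compounds, and the source may have more. Where it says the series, first, only, none or still open, it means among the compounds named here.

Measured in an ADME assay on the whole organism for inhibition, with Oryza sativa as the target, with a stated time of 4 days; a lower number here means a stronger inhibitor, a higher number a weaker inhibitor:
- compound 1 `C[C@H](Nc1nc(Cl)nc(NC(C)(C)C)n1)c1ccccc1`: 3310 nM
- compound 2 `CCCCNc1nc(Cl)nc(N[C@@H](C)c2ccccc2)n1`: 23400 nM

Compound 1 holds the lower number of the two. Compound 3 `C[C@@H](Nc1nc(Cl)nc(NC(C)(C)C)n1)c1ccccc1` changes it in one way: the two compounds have the same atoms and bonds and differ only in configuration as drawn: 1 of 1 stereo elements differ; a stereocentre at a saturated chain carbon is drawn S in compound 1 and R in compound 3. Among the measured compounds shown here, the only measured step, a 7.1-fold higher number from compound 1 to compound 2 (0.85 log units; beyond the scatter), replaces a group on a nitrogen and leaves that stereocentre as drawn, so it bears only indirectly and gives no direction. It does show that a single change can move beyond the scatter, so the range stays wide. The expected step, a 1.2-fold higher number from compound 1 to compound 3 (0.08 log units; within the scatter), is small and stays within the scatter. Compound 3 is estimated at 4000 nM (expected range 700 nM to 25000 nM).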

Compound 3, half-maximal inhibitory concentration: 9330 nM
Compound 3: the middle estimate sits 2.3-fold (0.37 log units) below what was measured, and the stated range covers the measured number.
By their numbers in this assay, from the lowest: compound 1; then compound 3; then compound 2.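

In this assay, inverting the stereocentre at the saturated chain carbon gives a 2.8-fold higher number from compound 1 to compound 3 (0.45 log units; beyond the scatter) and so shows that configuration at this position can move the number beyond the scatter. The earlier step changed a group on a nitrogen and kept this stereocentre as drawn, whereas this gap can be put down to configuration alone because nothing else separates the pair: the fact that compounds 1 and 3 differ only in the configuration as drawn.

On these data alone, whether the S drawing keeps the lower number with butyl on the nitrogen remains open. So does how a methoxy group in place of the chlorine would read at either configuration.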